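Trifluoromethyl for chloro on the anilide ring of compound 1

A few compounds are considered here, and "the series" means these few. Any claim that something is new, unique, unknown or untested is made for them only; others in the source may bear on it.

Measured compounds:
compound 1, `O=C(CN1CCN(c2nnc(Cc3ccncc3)c3ccccc23)CC1)Nc1ccc(F)c(Cl)c1`, 4 nM
compound 2, `Cc1ccc(F)cc1NC(=O)CN1CCN(c2nnc(Cc3ccccc3)c3ccccc23)CC1`, 19200 nM
compound 3, `O=C(CN1CCN(c2nnc(Cc3ccccc3)c3ccccc23)CC1)Nc1ccc(F)c(Cl)c1`, 7360 nM

In a functional assay on MDA-MB-231 cells (Homo sapiens) for cytotoxicity, read by MTT assay, with a stated time of 72 h (on this read-out higher numbers stand for weaker inhibition and lower numbers for stronger inhibition), compound 1 gives the lowest number of the three: compound 3 lies a 1800-fold higher number from compound 1 to compound 3 (3.26 log units; beyond the scatter), and compound 2 stands further away still. The unmeasured compound 4, `O=C(CN1CCN(c2nnc(Cc3ccncc3)c3ccccc23)CC1)Nc1ccc(F)c(C(F)(F)F)c1`, differs from compound 1 in one place: trifluoromethyl in place of chloro on an aromatic carbon.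

Among the compounds with values here, none of the measured steps changes the same group. The step from compound 1 to compound 3 concerns the pyridin-4-yl and is far larger than anything expected here. The step from compound 2 to compound 3, a 2.6-fold lower number from compound 2 to compound 3 (0.42 log units; beyond the scatter), is the only one that touches the anilide ring, and it is modest; it shows that changes on that ring move this assay by a small amount only. For compound 4 a small loss beyond the scatter is therefore expected, about a 2.3-fold higher number from compound 1 to compound 4 (0.35 log units; beyond the scatter). Compound 4 is estimated at 9 nM, with a range of 2.5 nM to 40 nM.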

Compound 4, half-maximal inhibitory concentration: 1.9 nM
Compound 4: middle estimate off by 4.7-fold (0.68 log units), on the high side; measured number below the stated range.
By their numbers in this assay, from the lowest: compound 4; then compound 1; then compound 3; then compound 2.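

In this assay, the aromatic carbon ortho to a fluoro group accepts trifluoromethyl in place of chloro, four heavy atoms for one, with no loss: the change gives a 2.1-fold lower number from compound 1 to compound 4 (0.32 log units; beyond the scatter). Within the data shown here, until now the only step on this ring was a 2.6-fold lower number from compound 2 to compound 3 (0.42 log units; beyond the scatter), which replaced the whole substituted phenyl on the amide-type nitrogen in compounds with phenyl rather than pyridin-4-yl, whereas this step changes a single group and keeps the pyridin-4-yl. Nothing measured here accounts for the lower number.

The compounds shown leave open whether a bromo, a nitrile or a methoxy group on this same carbon would keep the number as low. They also leave open whether trifluoromethyl in place of chloro would move compound 3 in the same direction.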